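Methyl on the Ring Nitrogen of Compound 1

The source may hold more compounds than are shown below. What is called first, only, known or untested is meant among the compounds shown, and "the series" means these compounds.

Compound 1 `COc1ccccc1/C=c1/[nH]c(=O)/c(=C\c2cccc(Cl)c2Cl)[nH]c1=O` was tested in a functional assay on HL-60 cells (Homo sapiens) for cytotoxicity, read by CCK-8 assay, with a stated time of 72 h (a higher number here means a weaker inhibitor, a lower number a stronger inhibitor), and there compound 1 gives "not active" (no number reported), so no single number places it among the others. Two related compounds that carry a substituent on the same ring nitrogen do give numbers: compound 2 `C=CCn1c(=O)/c(=C\c2cccc(F)c2)[nH]c(=O)/c1=C\c1ccccc1OC` gives 8890 nM, and compound 3 `C=CCn1c(=O)/c(=C\c2ccccc2OC)[nH]c(=O)/c1=C\c1ccccc1OC` gives 15700 nM. Within the data shown here, the one step measured between them, a 1.8-fold higher number from compound 2 to compound 3 (0.25 log units; within the scatter), concerns the aryl group and not the nitrogen. Compound 4 `COc1ccccc1/C=c1\c(=O)[nH]/c(=C/c2cccc(Cl)c2Cl)c(=O)n1C` differs from compound 1 by methyl in place of hydrogen on an aromatic nitrogen. Among the measured compounds shown here, no measured step covers this change, so nothing here sets its size or direction directly. What can be said is that compound 1, with hydrogen on that nitrogen, returns no number, while compounds 2 and 3, each with the nitrogen substituted, fall in a weak but measurable range. On that basis compound 4 is expected to give a number of the same order as compounds 2 and 3, though it may equally come back without one. The estimate for compound 4 is 15000 nM, with an expected range from 5000 nM to 60000 nM.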

Compound 4, half-maximal inhibitory concentration: 200 nM
The estimate for compound 4 lay 75-fold (1.88 log units) above the measured number; the whole stated range lies above it.
By their numbers in this assay, from the lowest: compound 4; then compounds 2 and 3 (each within the scatter of the next).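

With compound 1 at "not active" (no number reported) and compound 4 at 200 nM in this assay no step can be read between the two. The compounds shown leave open how large a change methyl in place of hydrogen on the aromatic nitrogen brings on a pair with two numbers. Nothing shown here bears on the reason for this result.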